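The source may report more compounds than this note shows. Statements on the series, on what has been measured and on what is new or still open speak of the compounds shown alone.

Three measured compounds share one core and differ only in the outer part of the biaryl unit. Within the data shown here, compound 1 `CCOC(=O)CCCCCOc1cccc(CN(C(=O)c2ccc(-c3cccnc3)cc2)C(C)C)c1` is the first of them. In an ADME assay on Raji cells (Homo sapiens) for cytotoxicity, read by CellTiter-Glo and resazurin assay, with a stated time of 72 h (on this read-out lower numbers stand for an effect already at smaller amounts and higher numbers for an effect only at larger amounts of compound), compound 1 gives > 26000 nM, which is a limit of the assay and not a number. Compound 2 `CCOC(=O)CCCCCOc1cccc(CN(C(=O)c2ccc(-c3cccc(Oc4ccccc4)c3)cc2)C(C)C)c1` is the second. In this assay compound 2 gives > 19600 nM, again a limit of the assay rather than a number. Compound 3 `CCOC(=O)CCCCCOc1cccc(CN(C(=O)c2ccc(-c3cccc(OCc4ccccc4)c3)cc2)C(C)C)c1` carries a benzyloxy group where compound 2 carries a phenoxy group. In this assay compound 3 gives > 26000 nM, which is also only a limit. Compound 3 thus stands among values that are all limits. The step that the two limits leave unreadable from compound 2 to compound 3 cannot be read in size or direction because its ends sit at the limit of > 19600 nM in this assay, at which 1 of the 3 values shown sits, and (the limit of > 26000 nM in this assay, at which 2 of the 3 values shown sit).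

Compound 4 `CCOC(=O)CCCCCOc1cccc(CN(C(=O)c2ccc(-c3cccc(OC)c3)cc2)C(C)C)c1` has not yet been measured. It differs from compound 3 by hydrogen in place of phenyl on a saturated chain carbon bound to an oxygen on an aromatic ring, that is, benzyloxy becomes methoxy. Among the measured compounds shown here, the only measured step that bears on this change is the one from compound 2 to compound 3, and it is unreadable because both ends are limits, as the limit of > 26000 nM in this assay, at which 2 of the 3 values shown sit, shows for two of the three values. No step beyond the scatter can therefore be expected in this assay, and the estimate for compound 4 is 30000 nM, ranging from 12000 nM to 100000 nM. The expected step that the limit leaves unreadable from compound 3 to compound 4 is accordingly close to none.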

Compound 4, half-maximal effective concentration: > 21000 nM
Compound 4: no number, only a limit; the forecaster's own chance of this, stated with the estimate: 85%; the middle value lies beyond the limit too.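

In this assay compound 4 gives > 21000 nM, which is a limit of the assay and not a number. The steps to compound 4 from compound 1, compound 2 and compound 3 cannot be read in size or direction: the limit of > 21000 nM in this assay, at which 1 of the 4 values shown sits. The compounds shown leave open at what concentration any of them has an effect in this assay, and whether the groups that differ among them change it.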